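Thiophen-2-yl for Acetyl on Two Related Cores

The compounds below may be only part of what the source reports. "The series", "measured", "known", "first", "only" and "open" are said of these compounds alone.

Compound 1 `CC(=O)OC1=CC(=O)c2ccccc2C1=O` carries an acetyl group on an oxygen attached to an unsaturated carbon. In a functional assay on HeLa cells (Homo sapiens) for cytotoxicity (on this read-out higher numbers stand for weaker inhibition and lower numbers for stronger inhibition), compound 1 gives 62100 nM. Compound 2 `O=C1C=C(Oc2cccs2)C(=O)c2ccccc21` differs from it by thiophen-2-yl in place of acetyl on an oxygen on an unsaturated carbon, and in this assay compound 2 gives 35300 nM; the resulting step is a 1.8-fold lower number from compound 1 to compound 2 (0.25 log units; within the scatter). Compound 3 `CC(=O)Oc1ccc2c(c1)C(=O)C=CC2=O` is built from the same atoms as compound 1, joined differently; the difference between the two cores is not broken down here. In this assay compound 3 gives 27700 nM. Against compound 2 this lies within the scatter, while against compound 1 the gap is beyond it.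

Compound 4 `O=C1C=CC(=O)c2cc(Oc3cccs3)ccc21` has not yet been measured. It differs from compound 3 by thiophen-2-yl in place of acetyl on an oxygen on an aromatic ring. Within the data shown here, this is the same kind of change as the one made from compound 1 to compound 2, but not the same: in the earlier pair the oxygen sits on an unsaturated carbon whose other neighbours are a double-bonded ring carbon, whereas here it sits on an aromatic ring whose other neighbours are aromatic carbon. Only one earlier occurrence of this change is available, and it sits on a different core. The step is nevertheless expected to be modest, a 1.5-fold lower number from compound 3 to compound 4 (0.19 log units; within the scatter), because the earlier step of a 1.8-fold lower number from compound 1 to compound 2 (0.25 log units; within the scatter) stayed within the scatter. In this assay compound 4 is therefore estimated at about 18000 nM, most likely between 8000 nM and 45000 nM.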

Compound 4, half-maximal inhibitory concentration: 8860 nM
The estimate for compound 4 lay 2.0-fold (0.31 log units) above the measured number, within the range that was stated.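

In this assay the exchange of acetyl for thiophen-2-yl on the core of compound 3 gives a 3.1-fold lower number from compound 3 to compound 4 (0.50 log units; beyond the scatter) and runs in the same direction as on the core of compound 1, and the two steps cannot be told apart: the same change on two cores in this assay, a 1.8-fold lower number (0.25 log units; within the scatter) from compound 1 to compound 2 and a 3.1-fold lower number (0.50 log units; beyond the scatter) from compound 3 to compound 4, 1.8-fold (0.25 log units) apart, within the scatter of two such steps. The change therefore carried over from one core to the other with its direction kept and with a size that cannot be separated from the earlier one, even though only the newer step lies beyond the scatter on its own. This does not show that the core of compound 3 responds more strongly than the core of compound 1, and two pairs of compounds are too few to set a rule for any further core in this series.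

The compounds shown place only acetyl and thiophen-2-yl on this oxygen, so it remains open whether a phenyl ring, a longer alkyl chain or a chain ending in an amine or a carboxylic acid would move the number in the same direction on both cores. From the compounds shown here alone, it also remains open whether the two cores would keep step with each other once the group on the oxygen is something other than thiophen-2-yl.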